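Adding a Second Hydroxy Group in a Cytotoxic Series

This account rests on a few compounds, and the source may have more. Where it says the series, first, only, none or still open, it means among the compounds named here.

Measured compounds:
compound 1, `Cn1c(/C=C/C(=O)c2cccc(O)c2)cc(Br)c1Br`: 12800 nM
compound 2, `Cn1c(/C=C/C(=O)c2ccc(O)cc2O)cc(Br)c1Br`: 1610 nM
compound 3, `Cn1c(/C=C/C(=O)c2ccc(O)cc2)cc(Br)c1Br`: 3120 nM

The three measured compounds share a core and differ only in where hydroxy groups sit on one ring. In a functional assay on MCF7 cells (Homo sapiens) for cytotoxicity, read by MTT assay, with stated times of 6 h and 48 h (a lower number here means a stronger inhibitor, a higher number a weaker inhibitor), compound 1 gives the highest number of the three; how the core of compound 1 differs from the core of compound 3 is not broken down here. Compound 3 and compound 2 differ by one change, (hydroxy in place of hydrogen on an aromatic carbon), and this gave a 1.9-fold lower number from compound 3 to compound 2 (0.29 log units; within the scatter).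

Compound 4, `Cn1c(/C=C/C(=O)c2cc(O)ccc2O)cc(Br)c1Br`, has not been measured in this assay. It differs from compound 1 by hydroxy in place of hydrogen on an aromatic carbon. Within the data shown here, this is the same kind of change as the one from compound 3 to compound 2, though the surroundings are not identical: in both cases the new group is ortho to a large group, but in one case it is meta to a hydroxy group and in the other para to a hydroxy group. On the strength of the earlier step, a change of about a 1.8-fold lower number from compound 1 to compound 4 (0.26 log units; within the scatter) is expected. Compound 4 is therefore estimated at 7000 nM, likely between 2500 nM and 18000 nM.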

Compound 4, half-maximal inhibitory concentration: 320 nM
For compound 4 the middle estimate is 22-fold (1.34 log units) above the measured one; the whole stated range lies above it.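

In this assay, putting a hydroxy group in place of hydrogen on an aromatic carbon, ortho to a large group and para to a hydroxy group, gave a 40-fold lower number from compound 1 to compound 4 (1.60 log units; beyond the scatter), which is a large step. The same change therefore did not carry over from one core to the other at the same size: the same change on two cores in this assay, a 1.9-fold lower number (0.29 log units; within the scatter) from compound 3 to compound 2 and a 40-fold lower number (1.60 log units; beyond the scatter) from compound 1 to compound 4, 21-fold (1.31 log units) apart, beyond the scatter of two such steps

This shows that, in this series, the size of the step from one pair cannot simply be transferred to another pair, but it does not show why the two steps differ, and two pairs give no rule for any further core.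

The compounds shown leave open whether the large step needs a hydroxy group specifically, since no methoxy group, amine or fluorine appears at that place for comparison. They also leave open whether a similar step would appear with the two bromine atoms on the shared core replaced by other groups, such as chlorine or methyl.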